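This account rests on a few compounds, and the source may have more. Where it says the series, first, only, none or still open, it means among the compounds named here.

Measured so far in a functional assay on JAR cells (Homo sapiens) for inhibition, read by MTT assay, with a stated time of 72 h, tested at 10 uM; on this read-out higher numbers stand for more inhibition at the one concentration tested (going by the name of the read-out) and lower numbers for less inhibition:
- compound 1, `CCOC(=O)C1=C(Nc2ccccc2)S/C(=C\c2ccc(C(=O)O)cc2)C1=O`: 16.8%
- compound 2, `CCOC(=O)C1=C(Nc2ccccc2)S/C(=C\c2ccc[nH]2)C1=O`: 49.2%
- compound 3, `CCOC(=O)C1=C(Nc2ccc(C(F)(F)F)cc2)S/C(=C\c2ccc[nH]2)C1=O`: 38.5%

Compound 2 stands highest of the three numbers. Its nearest neighbour is compound 3, reached by a step of a number 10.7 percentage points lower from compound 2 to compound 3 (beyond the scatter), a trifluoromethyl in place of hydrogen on an aromatic carbon. Its furthest neighbour is compound 1: the step of a number 32.4 percentage points higher from compound 1 to compound 2 (beyond the scatter), a 1H-pyrrol-2-yl in place of 4-carboxyphenyl on a double-bonded chain carbon bound to a double-bonded ring carbon.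

Compound 4, `CCOC(=O)C1=C(Nc2ccccc2)S/C(=C\c2cc3cnccc3[nH]2)C1=O`, has not yet been measured in this assay. It differs from compound 2 in one place: a group of 9 heavy atoms (7 carbon, 2 nitrogen; one five-membered aromatic ring with 1 hetero atom, one six-membered aromatic ring with 1 hetero atom) in place of a group of 5 heavy atoms (4 carbon, 1 nitrogen; one five-membered aromatic ring with 1 hetero atom), on a double-bonded chain carbon bound to a double-bonded ring carbon

Going by the values given here, the step that bears on this change is the one from compound 1 to compound 2, since it alters the same place; it was large and upward. The step from compound 2 to compound 3 touches another place and was modest. Among the compounds with values here, no measured step, however, puts a two-ring group at this place, so the size of the coming step is open. Compound 4 is expected to stay near compound 2, with the expected step being a number 5.2 percentage points lower from compound 2 to compound 4 (within the scatter), a change not clearly beyond the scatter in either direction. Compound 4 is therefore estimated at 44%, within a range from 20% to 68%.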

Compound 4, a percentage reported as inhibition, at one concentration (the size of the read-out at that concentration, not a potency): < 10%
Compound 4: only a limit was reported; the forecaster's own chance of this, stated with the estimate: 0%; middle value at least 34 percentage points away from the limit.
By their numbers in this assay, from the lowest: compound 1; then compound 3; then compound 2. At a limit, below all of these: compound 4.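

In this assay, compound 4 returned only a limit and not a number: the limit of < 10% in this assay, at which 1 of the 4 values shown sits.

Until now, this place on a double-bonded chain carbon bound to a double-bonded ring carbon had only shown 1H-pyrrol-2-yl reading higher than 4-carboxyphenyl, but the new group shows that retaining a five-membered aromatic ring with 1 hetero atom and 1 hydrogen-bond donor does not preserve that reading once a six-membered aromatic ring with 1 hetero atom is also present, with a number at least 39.2 percentage points lower from compound 2 to compound 4 (beyond the scatter). Measured against the 4-carboxyphenyl group at the same place, the result is a number at least 6.8 percentage points lower from compound 1 to compound 4 (that floor lies within the scatter), and that floor does not separate the two compounds.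

The compounds shown leave open whether the loss goes with the added six-membered ring as a whole or with its nitrogen, since none carries indol-2-yl, the matching two-ring group with carbon in place of that ring nitrogen. They also leave open how a five-membered group such as furan-2-yl would read at this place, and whether the trifluoromethyl step seen on the 1H-pyrrol-2-yl series would carry over to the two-ring group.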